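A few compounds are considered here, and "the series" means these few. Any claim that something is new, unique, unknown or untested is made for them only; others in the source may bear on it.

Of the compounds shown here, two sharing one core have been measured in a physicochemical assay for lipophilicity; a higher number here means a more lipophilic compound, a lower number a more polar compound. Compound 1 `Fc1cccc(F)c1C1=NC(c2ccccc2)CO1` gives 3.01 in this assay. Compound 2 `COc1cccc(C2=NC(c3ccccc3)CO2)c1` gives 3.77 in this assay. Of these two numbers, compound 1 stands lowest; its nearest neighbour is compound 2, whose value lies higher by an amount beyond the usual scatter of repeated measurements. Among the compounds with values here, no pair of measured compounds differs in one place only, so there is no measured step that could be used to calibrate the next change directly.

Compound 3 `Fc1cccc(Cl)c1C1=NC(c2ccccc2)CO1` has not yet been measured. It differs from compound 1 in a single place: chloro in place of fluoro on an aromatic carbon. The two compounds are otherwise identical, so compound 3 tests this one exchange in this assay.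

Within the data shown here, with no measured step of this kind at hand, the expectation rests on the structural change alone. The step from compound 1 to compound 3 is expected to be a number 0.59 log units higher from compound 1 to compound 3 (beyond the scatter), an increase beyond the scatter. Compound 3 is therefore expected to give about 3.6 in this assay, with a likely range from 3.3 to 3.9. The measurement will show whether that expectation holds.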

Compound 3, partition coefficient: 3.45
The estimate for compound 3 lay 0.15 log units above the measured number; measured number inside the range.
By their numbers in this assay, from the lowest: compound 1; then compound 3; then compound 2.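

The earlier compounds shown here offered no step that could be read in one place, and this exchange gives the first: in this assay, chloro in place of fluoro on an aromatic carbon, ortho to a large group, amounts to a number 0.44 log units higher from compound 1 to compound 3 (beyond the scatter). For this position, the exchange of one heavy atom for one heavy atom is enough to carry the number beyond the scatter, although neither group brings a ring, a hydrogen-bond donor, a hydrogen-bond acceptor or a net charge. Nothing available explains the size or direction of this step.

The compounds shown give only this one exchange at this one position, so where a bromo or a methyl group placed there would fall in this assay remains open. Also open, on these data alone, is whether a second chloro, taking the place of the remaining fluoro group, would add a step of similar size or a different one.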